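A few compounds are considered here, and "the series" means these few. Any claim that something is new, unique, unknown or untested is made for them only; others in the source may bear on it.

Working notes on the fluorinated pentol series. Compound 1 `OCC(O)C(O)C(O)COC/C=C/C(F)(F)C(F)(F)C(F)(F)C(F)(F)C(F)(F)C(F)(F)F` and compound 2 `OCC(O)C(O)C(O)COC/C=C/C(F)(F)C(F)(F)C(F)(F)C(F)(F)C(F)(F)C(F)(F)C(F)(F)C(F)(F)F` carry the fluorinated tail on an ether-linked alkene, while compound 3 `O=C(CCC(F)(F)C(F)(F)C(F)(F)C(F)(F)C(F)(F)F)OCC(O)C(O)C(O)CO` joins its tail through an ester. In a physicochemical assay for solubility (on this read-out higher numbers stand for higher solubility and lower numbers for lower solubility), compound 1 gives < 1000 ug/mL, which is a limit of the assay and not a number. In this assay compound 2 gives 50 ug/mL. Compound 3 gives 500 ug/mL, the higher of the two readable numbers; the nearest, compound 2, sits lower by a gap beyond the scatter. Within the data shown here, the single step between compounds that differ in one place, a step that the limit leaves unreadable from compound 1 to compound 2, has no readable size because the limit of < 1000 ug/mL in this assay, at which 1 of the 3 values shown sits, covers compound 1.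

Compound 4 `O=C(CCC(F)(F)C(F)(F)C(F)(F)C(F)(F)C(F)(F)C(F)(F)C(F)(F)C(F)(F)F)OCC(O)C(O)C(O)CO` differs from compound 3 by 1,1,2,2,3,3,3-heptafluoropropyl in place of fluoro on a saturated chain carbon bound to two fluorine atoms and a saturated chain carbon. Among the measured compounds shown here, this is a lengthening of the fluorinated tail, and the only measured step of that kind is unreadable, so no direct size is available. What the numbers do show is that compound 2, with the longer tail of the ether pair, gives a lower value in this assay than compound 3, although those two differ in more than one place. A lowering is therefore expected, of roughly a 17-fold lower number from compound 3 to compound 4 (1.22 log units; beyond the scatter). Compound 4 is estimated at 30 ug/mL, with a range from 5 ug/mL to 200 ug/mL.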

Compound 4, solubility: < 10 ug/mL
Compound 4 ended at the assay's limit; the forecaster's own chance of this, stated with the estimate: 15%; middle value at least 3.0-fold (0.47 log units) away from the limit.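

Compound 4 gives the series its first readable size for lengthening the fluorinated tail: placing 1,1,2,2,3,3,3-heptafluoropropyl in place of fluoro, on a saturated chain carbon bound to two fluorine atoms and a saturated chain carbon, gives an at least 50-fold lower number from compound 3 to compound 4 (1.69 log units; beyond the scatter). In this assay compound 4 gives < 10 ug/mL, which is a limit of the assay and not a number. Among these compounds, the step is large, and it holds for the ester-linked pair, where the entering group adds no ring, no hydrogen-bond donor or acceptor and no net charge, whereas the one earlier step of this kind, in the ether-linked alkene pair, cannot be read.

Whether the same change has a comparable size on the ether-linked alkene tail remains open, and so does the effect of the linkage itself, as the ether-linked and ester-linked compounds shown differ in more than one place. Also open, from the compounds shown here alone, is how the pentol core with the same fluorinated tails would read with an amide in place of the ester, or with an amine or a carboxylic acid added to the tail.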